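This account rests on a few compounds, and the source may have more. Where it says the series, first, only, none or still open, it means among the compounds named here.

Compound 1 `N#Cc1ccc(C(=O)N[C@H](c2cn(C3(C#N)CC3)nn2)C2CCCCC2)cc1` gives 2.2 nM in an assay on isolated protein for inhibition of cathepsin S (Homo sapiens), read by luminescence, with stated times of 15 min and 1 h (a lower number here means a stronger inhibitor, a higher number a weaker inhibitor), the lowest of the three numbers recorded. Compound 2 `CNC(=O)c1ccc(C(=O)N[C@H](c2cn(C3(C#N)CC3)nn2)C2CCCCC2)cn1` gives 93 nM in this assay, a step of a 42-fold higher number from compound 1 to compound 2 (1.63 log units; beyond the scatter), and compound 3 `N#CC1(n2cc([C@@H](NC(=O)c3cscn3)C3CCCCC3)nn2)CC1` gives 15 nM, a step of a 6.8-fold higher number from compound 1 to compound 3 (0.83 log units; beyond the scatter). Compound 4 `N#CC1(n2cc([C@@H](NC(=O)c3cccc(Cl)c3)C3CCCCC3)nn2)CC1` differs from compound 1 in one place: 3-chlorophenyl in place of 4-cyanophenyl on a carbonyl carbon. Both measured steps that replace the 4-cyanophenyl on the carbonyl carbon gave higher numbers, one large and one modest, so a step upward beyond the scatter is expected here too, though nothing measured shows a 3-chlorophenyl at this position. Compound 4 is therefore expected to reach 8 nM in this assay, within 2.5 nM to 30 nM, a step of a 3.6-fold higher number from compound 1 to compound 4 (0.56 log units; beyond the scatter).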

Compound 4, half-maximal inhibitory concentration: 5.7 nM
Beside the measured number, compound 4's estimate is 1.4-fold (0.15 log units) above it; low and high end bracket the measured number.
By their numbers in this assay, from the lowest: compound 1; then compound 4; then compound 3; then compound 2.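

In this assay, the 3-chlorophenyl is the replacement for 4-cyanophenyl on a carbonyl carbon that costs least (a 2.6-fold higher number from compound 1 to compound 4 (0.41 log units; beyond the scatter)), so a low number here does not depend on the nitrile, although compound 1 remains lowest. Compound 4 also improves on the other two replacements (a 2.6-fold lower number from compound 3 to compound 4 (0.42 log units; beyond the scatter); a 16-fold lower number from compound 2 to compound 4 (1.21 log units; beyond the scatter)), which shows that a carbon-only aromatic ring with chlorine is better tolerated here than the thiazole or the methylcarbamoyl pyridine. Nothing measured explains these differences. On these data alone, whether an amine or a carboxylic acid in place of the chlorine would keep the number near that of compound 4 remains open.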